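A few compounds are considered here, and "the series" means these few. Any claim that something is new, unique, unknown or untested is made for them only; others in the source may bear on it.

Series notes. The shared core, a biaryl ether chain ending in the iminosugar, is held fixed; only the outer aryl varies. In an assay on isolated protein for inhibition of ceramide glucosyltransferase (Homo sapiens) (a higher number here means a weaker inhibitor, a lower number a stronger inhibitor), compound 1 `COc1ccc(-c2ccc(COCCCCCN3C[C@H](O)[C@@H](O)[C@H](O)[C@H]3CO)cc2)cc1` gives 25 nM. Compound 2 `COc1cccc(-c2ccc(COCCCCCN3C[C@H](O)[C@@H](O)[C@H](O)[C@H]3CO)cc2)c1` gives 150 nM in this assay, the highest number of the three measured, with compound 3 nearest and compound 1 furthest from it. Compound 3 `COc1ccccc1-c1ccc(COCCCCCN2C[C@H](O)[C@@H](O)[C@H](O)[C@H]2CO)cc1` gives 50 nM in this assay. The measured steps are a 6.0-fold higher number from compound 1 to compound 2 (0.78 log units; beyond the scatter), a 3.0-fold lower number from compound 2 to compound 3 (0.48 log units; beyond the scatter) and a 2.0-fold higher number from compound 1 to compound 3 (0.30 log units; within the scatter), the last within the scatter.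

Next is compound 4 `OC[C@@H]1[C@@H](O)[C@H](O)[C@@H](O)CN1CCCCCOCc1ccc(-c2ccc(C(F)(F)F)cc2)cc1`, which differs from compound 2 in one place: 4-(trifluoromethyl)phenyl in place of 3-methoxyphenyl on an aromatic carbon. Going by the values given here, no measured step exchanges a methoxy for a trifluoromethyl, so that part of the change has no precedent. Among the compounds with values here, the step of a 6.0-fold higher number from compound 1 to compound 2 (0.78 log units; beyond the scatter) compares 4-methoxyphenyl with 3-methoxyphenyl and is the only guide to the change of position; it points toward a lower number for compound 4, of modest size, with wide uncertainty from the unprecedented group. For compound 4 in this assay the expected value is 40 nM, in a range from 10 nM to 160 nM. The expected step is a 3.8-fold lower number from compound 2 to compound 4 (0.57 log units; beyond the scatter), toward a lower number.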

Compound 4, half-maximal inhibitory concentration: 20 nM
Beside the measured number, compound 4's estimate is 2.0-fold (0.30 log units) above it; the range from low to high includes it.
By their numbers in this assay, from the lowest: compounds 4, 1 and 3 (each within the scatter of the next, the first and the last beyond it); then compound 2.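

In this assay, on the aromatic carbon para to a large group, trifluoromethyl and methoxy cannot be told apart (a 1.3-fold lower number from compound 1 to compound 4 (0.10 log units; within the scatter)), so the hydrogen-bond acceptor counted in the methoxy group is not needed to keep the number low at this place. The 4-(trifluoromethyl)phenyl group also separates from both other methoxyphenyl isomers, with a 7.5-fold lower number from compound 2 to compound 4 (0.88 log units; beyond the scatter) and a 2.5-fold lower number from compound 3 to compound 4 (0.40 log units; beyond the scatter), the second of these being a gap beyond the scatter even though compound 3 lies within the scatter of compound 1. Thus two different groups at this one place both give numbers at the low end of the series, and the data shown offer no measured basis for explaining these steps.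

Trifluoromethyl appears here at only this one place, so whether it would follow the order seen for the methoxyphenyl isomers on other aromatic carbons stays open. As far as these compounds go, how a nitrile, a carboxylic acid or an amine on the same aromatic carbon would read in this assay also stays open, and with it how wide a range of groups this place accepts.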